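A few compounds are considered here, and "the series" means these few. Any claim that something is new, unique, unknown or untested is made for them only; others in the source may bear on it.

Three thiosemicarbazones have so far been tested in a functional assay on SW-620 cells (Homo sapiens) for antiproliferative activity, read by MTT assay, with a stated time of 72 h; a lower number here means a stronger inhibitor, a higher number a weaker inhibitor. Compound 1 `Oc1ccc2ccccc2c1/C=N/NC(=S)Nc1ccccc1` gives 300 nM. Compound 2 `COc1cccc(/C=N/NC(=S)Nc2ccccc2)c1O` gives 1600 nM, and compound 3 `CCN(CC)c1ccc(/C=N/NC(N)=S)c(O)c1` gives 3000 nM. Among these three numbers compound 2 stands second highest: its nearest neighbour is compound 3, whose number lies within the usual scatter of repeated measurements, while compound 1 lies beyond that scatter with the lower number.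

Compound 4 `Oc1ccccc1/C=N/NC(=S)Nc1ccccc1` has not yet been measured. Its change from compound 2 is hydrogen in place of methoxy on an aromatic carbon, and the rest of the molecule stays the same. Within the data shown here, no measured pair in this set isolates such a change, so there is no direct precedent for the size of the step. With the hydroxy group and the thiosemicarbazone part unchanged, the expectation is a step no larger than the scatter of this assay, in either direction. Compound 4 is therefore estimated at 1200 nM, with a range from 400 nM to 4000 nM. That estimate means an expected step of a 1.3-fold lower number from compound 2 to compound 4 (0.12 log units; within the scatter).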

Compound 4, half-maximal inhibitory concentration: 2000 nM
The estimate for compound 4 lay 1.7-fold (0.22 log units) below the measured number; the measured number falls inside the stated range.
By their numbers in this assay, from the lowest: compound 1; then compounds 2, 4 and 3 (each within the scatter of the next).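

In this assay, hydrogen in place of methoxy, on an aromatic carbon ortho to a hydroxy group, gives a 1.3-fold higher number from compound 2 to compound 4 (0.10 log units; within the scatter). Among these compounds, this is the first comparison here that isolates a single place, and it shows that the two numbers cannot be told apart: in this pair, the methoxy group can be exchanged for hydrogen without a step that the read-out can resolve. No measurement among these compounds bears on why the two numbers agree.

Going by these compounds, only hydrogen and methoxy are compared at this position, so it remains open whether an ethoxy group, an amine or a carboxylic acid on the same carbon would also leave the number within the scatter. One pair also cannot show whether this exchange would behave the same way on another aromatic carbon or another core.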